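The compounds below may be only part of what the source reports. "The series", "measured", "known", "first", "only" and "open" are said of these compounds alone.

Measured so far in a functional assay for inhibition of nuclear factor NF-kappa-B complex (Homo sapiens); on this read-out higher numbers stand for weaker inhibition and lower numbers for stronger inhibition:
compound 1, `COc1ccc2c(c1)OC(c1cc(OC)c(OC)c(OC)c1)C(C(=O)N(C)OC)=C2`, 11700 nM
compound 2, `COc1ccc2c(c1)OC(c1cc(OC)c(OC)c(OC)c1)C(C=O)=C2`, 13500 nM
compound 3, `CCCC(=O)C1=Cc2ccc(OC)cc2OC1c1cc(OC)c(OC)c(OC)c1`, 11700 nM

The three numbers sit together. Compound 2 carries the top figure of the set, but the gap to compound 1, a 1.2-fold higher number from compound 1 to compound 2 (0.06 log units; within the scatter), and the gap to compound 3, a 1.2-fold lower number from compound 2 to compound 3 (0.06 log units; within the scatter), both fall inside the scatter, so the three compounds are not separated by this assay. The same holds for no change at the digits printed from compound 1 to compound 3 (within the scatter).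

Compound 4, `COc1ccc2c(c1)OC(c1cc(OC)c(OC)c(OC)c1)C=C2`, is the unmeasured member. Its change from compound 2: hydrogen in place of formyl on a double-bonded ring carbon. Every measured step swaps the group on a carbonyl carbon while keeping the carbonyl itself; none of them removes it. Within the data shown here, they show only that the group on that carbon, whether methoxy(methyl)amino, hydrogen or propyl, leaves the number unmoved within the scatter. Removing the formyl altogether is a step of a different kind, and the data give no direct reading on it. The working expectation is therefore a number near that of compound 2, with no step beyond the scatter, but with a wider range to cover the untested kind of change.

For compound 4 the estimate in this assay is 13500 nM, within 5000 nM to 36000 nM. This estimate means a step of no change at the digits printed from compound 2 to compound 4 (within the scatter).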

Compound 4, half-maximal inhibitory concentration: 17700 nM
Compound 4: middle estimate off by 1.3-fold (0.12 log units), on the low side; low and high end bracket the measured number.
By their numbers in this assay, from the lowest: compounds 1, 3, 2 and 4 (each within the scatter of the next).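

Removing the whole carbonyl-bearing group from the double-bonded ring carbon is a different kind of change from the earlier swaps, and in this assay the three readings of it are a 1.3-fold higher number from compound 2 to compound 4 (0.12 log units; within the scatter) and a 1.5-fold higher number from compound 3 to compound 4 (0.18 log units; within the scatter) and a 1.5-fold higher number from compound 1 to compound 4 (0.18 log units; within the scatter), so none of them separates hydrogen from the groups it replaces. The earlier steps shown here only exchanged what sat on the carbonyl carbon, whereas these steps show that the carbonyl itself, whether as formyl, propylcarbonyl or methoxy(methyl)carbamoyl, is not required at this position for a number in this range. With hydrogen included, the four compounds form one flat set in which no substituent at this position stands apart.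

The compounds shown leave open whether a carboxylic acid, an aminomethyl group or a longer acyl chain such as octanoyl on this carbon would separate from these four in this assay, and whether changes elsewhere on the shared core would do so. From the compounds shown here alone, what sets the common level of these numbers also stays open, as no accompanying measurement bears on it.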